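A few compounds are considered here, and "the series" means these few. Any claim that something is new, unique, unknown or untested is made for them only; others in the source may bear on it.

Measured compounds:
- Compound 1, `COc1cc(-c2cc(=O)c3cc(O)ccc3o2)cc(OC)c1OC`: in a functional assay on Malme-3M cells (Homo sapiens) for cytotoxicity, read by MTT assay, with a stated time of 6 days (on this read-out lower numbers stand for an effect already at smaller amounts and higher numbers for an effect only at larger amounts of compound), compound 1 gives only a limit, > 25 ug/mL.
- Compound 2, `COc1cc(-c2cc(=O)c3ccc(O)cc3o2)cc(OC)c1OC`: in this assay compound 2 gives only a limit, > 25 ug/mL.
- Compound 3, `COc1cc(-c2cc(=O)c3cc(O)ccc3o2)cc(OC)c1O`: in this assay compound 3 gives only a limit, > 25 ug/mL.

None of the three measured compounds reaches a number in this assay; every value stands at the limit of > 25 ug/mL in this assay, at which 3 of the 3 values shown sit. Compound 2 and compound 3 share much of their build, but the difference between their two cores is not broken down here, and each of them is known only as a limit.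

Among the compounds with values here, the one change that can be followed between measured compounds is methyl in place of hydrogen on an oxygen on an aromatic ring. Its step, a step that the two limits leave unreadable from compound 3 to compound 1, cannot be read, since both ends of it are limits.

Compound 4, `COc1ccc2c(=O)cc(-c3cc(OC)c(OC)c(OC)c3)oc2c1`, is the compound still to be measured. It stands to compound 2 exactly as compound 1 stands to compound 3: the change is methyl in place of hydrogen on an oxygen on an aromatic ring, the same change at the same kind of place. Within the data shown here, with both partners of the earlier pair sitting at the limit, that pair gives no size for the step, and the expectation for compound 4 rests only on the fact that compound 2 itself gives a limit. The step from compound 2 to compound 4 is therefore expected to be about a step that the limit leaves unreadable from compound 2 to compound 4, meaning no readable movement. Compound 4 is expected to give about 30 ug/mL in this assay, most likely again as a limit, with a range estimated from 10 ug/mL to 100 ug/mL.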

Compound 4, concentration for half-maximal effect: > 25 ug/mL
Compound 4: a limit, no number (the forecaster's own chance of this, stated with the estimate: 80%); the middle value does not contradict the limit.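

In this assay compound 2 and compound 4 both give only a limit, so no size can be read for the change from hydroxy to methoxy between them. What the compounds shown leave open is whether this change moves the read-out at all, and whether any of the four reaches in this assay a half-maximal effect that can be given as a number.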